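A sulfanyl group added to compound 2

The compounds below may be only part of what the source reports. "The series", "measured", "known", "first", "only" and "open" are said of these compounds alone.

In an ADME assay on the whole organism (strain Sprague-Dawley) for pharmacokinetics, with Rattus norvegicus as the target, read by HPLC, at a dose of 1 mg/kg by the subcutaneous route (a higher number here means more compound in the circulation at the dose given, a lower number less compound in the circulation), compound 1 `O=C(Nc1nc2ccccc2s1)c1ccc(OC(F)F)c(OCC2CC2)c1` gives 245 nM and compound 2 `O=C(Nc1ccc2ncsc2c1)c1ccc(OC(F)F)c(OCC2CC2)c1` gives 221 nM. Going by the values given here, the only measured step, a 1.1-fold lower number from compound 1 to compound 2 (0.04 log units; within the scatter), comes with 1,3-benzothiazol-6-yl in place of 1,3-benzothiazol-2-yl on an amide-type nitrogen. The two measured compounds therefore stand level, with no order between them.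

Compound 3 `O=C(Nc1ccc2nc(S)sc2c1)c1ccc(OC(F)F)c(OCC2CC2)c1` is still unmeasured and differs from compound 2 by one change: sulfanyl in place of hydrogen on an aromatic carbon. In words, this is sulfanyl in place of hydrogen on an aromatic carbon. Among the compounds with values here, no measured pair shows this change, so the step of a 1.1-fold lower number from compound 1 to compound 2 (0.04 log units; within the scatter) bears on it only loosely: it is small, but it involves a different replacement. The data therefore give no firm direction, and the expectation stays near the value of compound 2, 221 nM, with a wide range. In this assay, the expected change is a 1.3-fold lower number from compound 2 to compound 3 (0.10 log units; within the scatter), which would not be a step beyond the scatter. For compound 3 the estimate is 175 nM, with an expected range from 60 nM to 450 nM.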

Compound 3, maximal plasma concentration: 270 nM
Beside the measured number, compound 3's estimate is 1.5-fold (0.19 log units) below it, and the stated range covers the measured number.
By their numbers in this assay, from the lowest: compounds 2, 1 and 3 (each within the scatter of the next).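

Sulfanyl in place of hydrogen on the aromatic carbon, next to the ring nitrogen and next to the ring sulfur, gives a 1.2-fold higher number from compound 2 to compound 3 (0.09 log units; within the scatter) in this assay, so this change leaves compound 3 level with compound 2. The earlier compounds shown here carried only hydrogen on this carbon and varied only the attachment of the amide nitrogen, whereas this pair shows that the position can take a group with one sulfur atom, one hydrogen-bond donor and one hydrogen-bond acceptor without a step beyond the scatter in this assay. Nothing available explains why the number stays level.

The compounds shown leave open whether this carbon would stay as undemanding with a different group, such as an amine, a methoxy group or a carboxylic acid, since sulfanyl is the only replacement for hydrogen seen here. They also leave open whether the same level reading would hold at another dose or by another route, because all three numbers come from a single subcutaneous dose.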